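Methylation of a phenol in an arylpiperazine series

A few compounds are considered here, and "the series" means these few. Any claim that something is new, unique, unknown or untested is made for them only; others in the source may bear on it.

Compound 1 `COc1ccccc1N1CCN(CCCNc2ncccc2C(=O)N(C)C)CC1` gives 1.59 nM in a functional assay for antagonist activity at Alpha-1A adrenergic receptor (Oryctolagus cuniculus); a lower number here means tighter binding, a higher number weaker binding. Compound 2 `CN(C)C(=O)c1cccnc1NCCCN1CCN(c2ccccc2O)CC1` gives 5.01 nM, and compound 3 `COc1cc(O)ccc1N1CCN(CCCNc2ncccc2C(=O)N(C)C)CC1` gives 12.6 nM, the highest number of the three. The change from compound 2 to compound 1 is methyl in place of hydrogen on an oxygen on an aromatic ring, and it made a 3.2-fold lower number from compound 2 to compound 1 (0.50 log units; beyond the scatter). Compound 4 `COc1ccc(N2CCN(CCCNc3ncccc3C(=O)N(C)C)CC2)c(OC)c1` is not yet measured; it differs from compound 3 by methyl in place of hydrogen on an oxygen on an aromatic ring, the same change at the same kind of place as before. The two cores differ by 4-hydroxy-2-methoxyphenyl in place of 2-hydroxyphenyl on an amine nitrogen in a ring, which carried a 2.5-fold higher number from compound 2 to compound 3 (0.40 log units; beyond the scatter). For compound 4 the expected step is a 2.5-fold lower number from compound 3 to compound 4 (0.40 log units; beyond the scatter), resting on the single earlier occurrence of this change, which gave a 3.2-fold lower number from compound 2 to compound 1 (0.50 log units; beyond the scatter); one precedent on a different core leaves the size uncertain. Compound 4 is estimated at 5 nM, with a range of 2 nM to 13 nM.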

Compound 4, dissociation constant: 31.6 nM
Compound 4: the middle estimate sits 6.3-fold (0.80 log units) below what was measured; the whole stated range lies below it.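

In this assay, methyl in place of hydrogen on the oxygen gives a 2.5-fold higher number from compound 3 to compound 4 (0.40 log units; beyond the scatter), so the earlier result does not carry over from one core to the other, and even the direction differs: the same change on two cores in this assay, a 3.2-fold lower number (0.50 log units; beyond the scatter) from compound 2 to compound 1 and a 2.5-fold higher number (0.40 log units; beyond the scatter) from compound 3 to compound 4, 7.9-fold (0.90 log units) apart, beyond the scatter of two such steps The 2,4-dimethoxyphenyl group also gives a 6.3-fold higher number from compound 2 to compound 4 (0.80 log units; beyond the scatter) and a 20-fold higher number from compound 1 to compound 4 (1.30 log units; beyond the scatter), the latter a large step for the added methoxy group. With one pair on each core, this shows that the change depends on the core, but not why, nor which of the two results is more typical of the series.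

Going by these compounds, it remains open how an ethoxy group or an amine in place of the added methoxy of compound 4 would behave. Whether either would follow the step seen on the core of compound 1 or the one seen on the core of compound 3 is also unresolved.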